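Amide heteroaryl swap on the piperidinyl-sulfonyl series

This account rests on a few compounds, and the source may have more. Where it says the series, first, only, none or still open, it means among the compounds named here.

Measured so far:
compound 1 `O=C(NCc1ccc(S(=O)(=O)N2CCCCC2)cc1)c1ccn2cncc2c1` — > 10000 nM
compound 2 `O=C(NCc1ccc(S(=O)(=O)c2cccc(C(F)(F)F)c2)cc1)c1cnc2nccn2c1` — 2 nM

In a functional assay on A2780 cells (Homo sapiens) for inhibition, read by sulforhodamine B assay, with a stated time of 72 h (a higher number here means a weaker inhibitor, a lower number a stronger inhibitor), compound 1 reaches only the limit of the assay, > 10000 nM, and no number. Compound 2 differs from compound 1 at several places. In this assay, among the compounds with values here, compound 2 gives 2 nM; with no single step connecting the two, the pair shows only how far apart the two ends of the set lie. Compound 1 thus sits at the weak end of what has been seen, as the limit of > 10000 nM in this assay, at which 1 of the 2 values shown sits, shows.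

Compound 3 `O=C(NCc1ccc(S(=O)(=O)N2CCCCC2)cc1)c1cc2ccncc2o1` changes compound 1 in one place: a group of 9 heavy atoms (7 carbon, 1 nitrogen, 1 oxygen; one five-membered aromatic ring with 1 hetero atom, one six-membered aromatic ring with 1 hetero atom) in place of a group of 9 heavy atoms (7 carbon, 2 nitrogen; one five-membered aromatic ring with 2 hetero atoms, one six-membered aromatic ring with 1 hetero atom), on a carbonyl carbon. The rest of compound 1 is kept. Without a measured step of this kind, the expectation for the step from compound 1 to compound 3 is no change beyond the scatter, an at least 1.1-fold lower number from compound 1 to compound 3 (0.04 log units; that floor lies within the scatter), with compound 3 expected to stay near the limit. Compound 3 is estimated at 9000 nM in this assay, in the range 1500 nM to 30000 nM.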

Compound 3, half-maximal inhibitory concentration: 29 nM
Estimate against measurement, compound 3: 310-fold (2.49 log units) above; measured number outside the range, below it.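

Within the data shown here, this is the first single-place step: with the rest of compound 1 kept, changing only the group on the carbonyl carbon gives an at least 340-fold lower number from compound 1 to compound 3 (2.53 log units; beyond the scatter) in this assay. Both groups have 9 heavy atoms and the same aromatic ring sizes, so a change in hetero atoms alone, with one ring nitrogen replaced by oxygen, is enough here, and the piperidinyl-sulfonyl part does not prevent a low number. The printed step is only a floor because compound 1 stands at a limit, not a number: the limit of > 10000 nM in this assay, at which 1 of the 3 values shown sits.

Still open, as far as these compounds go, is whether the oxygen itself matters or the different arrangement of the ring hetero atoms, since the two change together in this step. Also open, from the compounds shown here alone, is how a sulfur-containing fused group, or a single pyridine ring, would read on the same carbonyl carbon.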